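Ester variation and stability in simulated gastric fluid

The compounds below may be only part of what the source reports. "The series", "measured", "known", "first", "only" and "open" are said of these compounds alone.

Compound 1 `CCOc1cc(NC(=O)C2(NC(=O)c3ccc4c(C5CCCC5)c(-c5ncc(Cl)cn5)n(C)c4c3)CCC2)ccc1/C=C/C(=O)OCC(C)C`, 1.43 h; compound 2 `CCOc1cc(NC(=O)C2(NC(=O)c3ccc4c(C5CCCC5)c(-c5ncc(Cl)cn5)n(C)c4c3)CCC2)ccc1/C=C/C(=O)OCc1ccccc1`, 1.83 h.

In an ADME assay on stomach for pharmacokinetics, in simulated gastric fluid (a lower number here means that the compound disappears faster, a higher number that the compound lasts longer), compound 2 stands highest of the two numbers, but its nearest neighbour compound 1 sits within the scatter of it. The new compound 3 `CCOc1cc(NC(=O)C2(NC(=O)c3ccc4c(C5CCCC5)c(-c5ncc(Cl)cn5)n(C)c4c3)CCC2)ccc1/C=C/C(=O)OCC(=O)N1CCOCC1` carries (morpholin-4-yl)carbonyl in place of phenyl on a saturated chain carbon bound to an oxygen next to a carbonyl group. Among the compounds with values here, the only measured step, a 1.3-fold higher number from compound 1 to compound 2 (0.11 log units; within the scatter), changed the same position and stayed within the scatter; it is the sole guide. No step beyond the scatter is therefore expected, and compound 3 is estimated at 1.6 h, within 0.8 h to 3.2 h, a step of a 1.1-fold lower number from compound 2 to compound 3 (0.06 log units; within the scatter) in this assay.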

Compound 3, half-life: 0.85 h
The estimate for compound 3 lay 1.9-fold (0.27 log units) above the measured number; low and high end bracket the measured number.
By their numbers in this assay, from the lowest: compounds 3, 1 and 2 (each within the scatter of the next, the first and the last beyond it).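

In this assay, the position on a saturated chain carbon bound to an oxygen next to a carbonyl group now shows a step beyond the scatter, though a modest one: (morpholin-4-yl)carbonyl in place of phenyl gives a 2.2-fold lower number from compound 2 to compound 3 (0.33 log units; beyond the scatter). The same group in place of isopropyl gives a 1.7-fold lower number from compound 1 to compound 3 (0.23 log units; within the scatter), so among these compounds only the exchange for phenyl leaves the scatter. Nothing available here accounts for this step. Going by these compounds, whether an amine, a carboxylic acid or a longer chain at this carbon would shift the half-life further remains open, as does whether a simple methyl would.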